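This account rests on a few compounds, and the source may have more. Where it says the series, first, only, none or still open, it means among the compounds named here.

Compound 1 `O=C(Nc1ccc2sc(-c3cccc(F)c3)nc2c1)N1CCCCC1` stands in an ADME assay on HepG2 cells (Homo sapiens) for inhibition, read by resazurin assay, with a stated time of 48 h (on this read-out higher numbers stand for an effect only at larger amounts of compound and lower numbers for an effect already at smaller amounts), only at a limit of the assay: compound 1 gives > 50000 nM. Compound 2 `O=C(Nc1ccc2sc(-c3ccc(F)c(F)c3)nc2c1)N1CCC(F)CC1` likewise gives only a limit in this assay, > 50000 nM. Among the compounds with values here, both values sit at the limit of > 50000 nM in this assay, at which 2 of the 2 values shown sit, so no step between measured compounds can be sized here. Compound 3 `O=C(Nc1ccc2sc(-c3ccccc3F)nc2c1)N1CCCCC1` is not yet measured in this assay; it differs from compound 1 by 2-fluorophenyl in place of 3-fluorophenyl on an aromatic carbon. No step beyond the scatter is expected in this assay, since the limit of > 50000 nM in this assay, at which 2 of the 2 values shown sit, holds both measured values. Compound 3 is expected to give 80000 nM (range 30000 nM to 300000 nM), an expected step that the limit leaves unreadable from compound 1 to compound 3, most likely again reported as a limit.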

Compound 3, half-maximal effective concentration: > 50000 nM
Compound 3: no number, only a limit; the forecaster's own chance of this, stated with the estimate: 80%; the middle value lies beyond the limit too.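

No step can be read from compound 1 to compound 3 in this assay, since both results are limits: the limit of > 50000 nM in this assay, at which 3 of the 3 values shown sit.

The compounds shown leave open how 2-fluorophenyl and 3-fluorophenyl compare, and whether any compound in the series reaches a measurable value in this assay on this read-out.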